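The source may report more compounds than this note shows. Statements on the series, on what has been measured and on what is new or still open speak of the compounds shown alone.

Measured so far:
compound 1 `O=C1NC2(CC2c2ccc3cccc(OCc4ccccc4)c3n2)C(=O)N1c1ccc(F)cc1`: in a functional assay on the whole organism (strain Kunming) with Mus musculus as the target, in the maximal electroshock model, with a stated time of 0.5 h (on this read-out lower numbers stand for an effect already at smaller amounts and higher numbers for an effect only at larger amounts of compound), compound 1 gives 300 mg/kg
compound 2 `CCCCN1C(=O)NC2(CC2c2ccc3cccc(OCc4ccccc4)c3n2)C1=O`: in this assay compound 2 gives 300 mg/kg

Compound 2 stands level with compound 1 at the digits shown; the step of no change at the digits printed from compound 1 to compound 2 (within the scatter) lies within the scatter. Compound 3 `COc1ccc(N2C(=O)NC3(CC3c3ccc4cccc(OCc5ccccc5)c4n3)C2=O)cc1` differs from compound 2 by 4-methoxyphenyl in place of butyl on an amide-type nitrogen in a ring. Within the data shown here, the only step that bears on it is no change at the digits printed from compound 1 to compound 2 (within the scatter), where butyl in place of 4-fluorophenyl on an amide-type nitrogen in a ring left the read-out unchanged; compound 3 puts 4-methoxyphenyl on that nitrogen. The step to compound 3 is expected to stay within the scatter, no change at the digits printed from compound 2 to compound 3 (within the scatter). Compound 3 is estimated at 300 mg/kg in this assay, with a range of 100 mg/kg to 600 mg/kg.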

Compound 3, minimum effective dose: 30 mg/kg
Compound 3: the middle estimate sits 10-fold (1.00 log units) above what was measured; the measured number lies below the stated range.
By their numbers in this assay, from the lowest: compound 3; then compounds 1 and 2 (each within the scatter of the next).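

The substituent on the amide-type nitrogen in a ring does move the read-out in this assay: 4-methoxyphenyl in place of butyl gives a 10-fold lower number from compound 2 to compound 3 (1.00 log units; beyond the scatter), although the earlier swap of butyl for 4-fluorophenyl left it level. Methoxy in place of fluoro on an aromatic carbon gives a 10-fold lower number from compound 1 to compound 3 (1.00 log units; beyond the scatter), so an aromatic ring on that nitrogen is not sufficient alone, as compound 1 carries one without matching compound 3. Nothing available explains this difference.

On these data alone, whether the gain is specific to methoxy stays open, since ethoxy, hydroxy or dimethylamino on that phenyl ring would test it. The shared core is also unchanged throughout, leaving its contribution open.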